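Chain-linked amides on the shared core

This account rests on a few compounds, and the source may have more. Where it says the series, first, only, none or still open, it means among the compounds named here.

Of the compounds shown here, two with the shared core have been measured. Compound 1 `CCCOc1ccc(NC(=O)CSc2nnc(Cc3nn(C)c(=O)c4ccccc34)n2C)cc1` in an assay on isolated protein (Mus musculus) for inhibition of IL15-IL15 receptor (Homo sapiens), read by resazurin assay, with stated times of 30 min and 2.5 days (a lower number here means a stronger inhibitor, a higher number a weaker inhibitor), reaches only > 30000 nM, which is a limit of the assay and not a number. Compound 2 `CN(C(=O)CCCCCCCSc1nnc(Cc2nn(C)c(=O)c3ccccc23)n1C)c1ccc(Cl)cc1Cl` gives 11900 nM in this assay and stands as the only number shown in the series. The other value shown is the limit of > 30000 nM in this assay, at which 1 of the 2 values shown sits. Going by the values given here, no step between measured compounds that differ in one place is available, so the step to compound 3 `Cn1c(Cc2nn(C)c(=O)c3ccccc23)nnc1SCCCCCCCC(=O)Nc1ccc(Br)cc1Br` has no measured counterpart. Compound 3 differs from compound 2 by (2,4-dibromophenyl)amino in place of (2,4-dichlorophenyl)(methyl)amino on a carbonyl carbon. With nothing measured to anchor it, the step from compound 2 to compound 3 is expected to be a 1.0-fold higher number from compound 2 to compound 3 (0.00 log units; within the scatter), none beyond the usual scatter. Compound 3 is therefore estimated at 12000 nM in this assay, with a range from 3500 nM to 40000 nM.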

Compound 3, half-maximal inhibitory concentration: 1500 nM
Beside the measured number, compound 3's estimate is 8.0-fold (0.90 log units) above it; measured number outside the range, below it.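

Going by these compounds alone, on this carbonyl carbon, the choice of amine part matters in this assay: (2,4-dibromophenyl)amino in place of (2,4-dichlorophenyl)(methyl)amino gives a 7.9-fold lower number from compound 2 to compound 3 (0.90 log units; beyond the scatter), the first readable step. The exchange is composite, with bromine replacing chlorine and the amide hydrogen, counted as a hydrogen-bond donor, replacing the methyl group on nitrogen, and the step belongs to these changes taken together. Nothing shown gives a measured property that would account for this step.

On these data alone, how much of the step follows the halogen and how much the amide hydrogen remains open. (2,4-Dichlorophenyl)amino and (2,4-dibromophenyl)(methyl)amino on the same carbonyl carbon would separate the two, and a shorter saturated chain carrying (2,4-dibromophenyl)amino would test the role of the chain.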